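This account rests on a few compounds, and the source may have more. Where it says the series, first, only, none or still open, it means among the compounds named here.

Measured so far:
- compound 1 `COc1cc(NC(C)CCCNC(=O)Nc2cccc(F)c2)c2ncccc2c1` gives 19000 nM
- compound 2 `COc1cc(NC(C)CCCNC(=O)Nc2cccc(Cl)c2)c2ncccc2c1` gives 17000 nM

Within the data shown here, in a functional assay on L1210 cells (Mus musculus) for inhibition, read by MTT assay, with a stated time of 72 h (on this read-out higher numbers stand for weaker inhibition and lower numbers for stronger inhibition), compound 2 gives 17000 nM, within the scatter of compound 1, and these are the only two numbers so far. Compound 3 `COc1cc(NC(C)CCCNC(=O)Nc2ccc(Br)cc2)c2ncccc2c1` carries 4-bromophenyl in place of 3-chlorophenyl on an amide-type nitrogen, with 4-bromophenyl in place of 3-chlorophenyl on an amide-type nitrogen. Among the measured compounds shown here, the only measured step that bears on this is a 1.1-fold lower number from compound 1 to compound 2 (0.05 log units; within the scatter), a swap of chloro for fluoro that stays within the scatter. For the measured compounds named here, no measured compound carries 4-bromophenyl, so the evidence is thin. The expected step is a 1.1-fold lower number from compound 2 to compound 3 (0.03 log units; within the scatter), nothing beyond the scatter. For compound 3 the estimate is 16000 nM, with an expected range of 7000 nM to 35000 nM.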

Compound 3, half-maximal inhibitory concentration: 18000 nM
Estimate against measurement, compound 3: 1.1-fold (0.05 log units) below; measured number inside the range.
By their numbers in this assay, from the lowest: compounds 2, 3 and 1 (each within the scatter of the next).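

In this assay, 4-bromophenyl on the amide-type nitrogen gives a 1.1-fold higher number from compound 2 to compound 3 (0.02 log units; within the scatter) and a 1.1-fold lower number from compound 1 to compound 3 (0.02 log units; within the scatter). The earlier pair compared only 3-fluorophenyl and 3-chlorophenyl; these steps show that a change of both halogen and ring position also stays within the scatter across these three compounds. No evidence on the reason for this result is available.

With halogen and ring position changed together in compound 3, their separate contributions remain unresolved. Also open, on these data alone, is what an amine or a carboxylic acid on this phenyl ring would give.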